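The source may hold more compounds than are shown below. What is called first, only, known or untested is meant among the compounds shown, and "the series" means these compounds.

Notes on the series

Three compounds of the shared core have been run in an ADME assay on L6 cells (Rattus norvegicus) for cytotoxicity, read by fluorescence, with a stated time of 72 h; a higher number here means a weaker inhibitor, a lower number a stronger inhibitor. Compound 1 `CCN(CC)C(=O)CNC1CC2(N3CCN(C)CC3)CC(c3ccccc3)C1C(c1ccccc1)C2` gives 37900 nM there. Compound 2 `CN1CCN(C23CC(NC(=O)CCN4CCCC4)C(C(c4ccccc4)C2)C(c2ccccc2)C3)CC1` gives 42200 nM, and compound 3 `CN1CCN(C23CC(NC(=O)CN4CCCC4)C(C(c4ccccc4)C2)C(c2ccccc2)C3)CC1` gives 27800 nM. All three sit together: the step of a 1.4-fold lower number from compound 1 to compound 3 (0.13 log units; within the scatter) and the step of a 1.5-fold lower number from compound 2 to compound 3 (0.18 log units; within the scatter) are both within the scatter, as is the step of a 1.1-fold higher number from compound 1 to compound 2 (0.05 log units; within the scatter), so compound 3 cannot be set apart from compounds 1 and 2 on this read-out.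

The next step goes from compound 3 to compound 4 `CN1CCN(C23CC(NCCC(=O)N4CCCC4)C(C(c4ccccc4)C2)C(c2ccccc2)C3)CC1`. The structural change is 2-((pyrrolidin-1-yl)carbonyl)ethyl in place of ((pyrrolidin-1-yl)methyl)carbonyl on an amine nitrogen

Going by the values given here, every measured step so far has altered the same side chain on this amine nitrogen, and none of them moved the number beyond the scatter: a 1.1-fold higher number from compound 1 to compound 2 (0.05 log units; within the scatter), a 1.4-fold lower number from compound 1 to compound 3 (0.13 log units; within the scatter) and a 1.5-fold lower number from compound 2 to compound 3 (0.18 log units; within the scatter) cover a change of the amine, a change of chain length and a swap of the group on the chain carbon. Nothing in these three steps points to a shift in either direction for compound 4, so no step beyond the scatter is expected in this assay; the expected step is a 1.2-fold higher number from compound 3 to compound 4 (0.06 log units; within the scatter). Compound 4 is therefore estimated at 32000 nM in this assay, with a likely range from 14000 nM to 75000 nM.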

Compound 4, half-maximal inhibitory concentration: 21500 nM
Compound 4: middle estimate off by 1.5-fold (0.17 log units), on the high side, and the stated range covers the measured number.
By their numbers in this assay, from the lowest: compounds 4, 3, 1 and 2 (each within the scatter of the next).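

In this assay the amide carbonyl can leave the amine nitrogen of the side chain, turning (((pyrrolidin-1-yl)methyl)carbonyl)amino into (2-((pyrrolidin-1-yl)carbonyl)ethyl)amino, and the result is only a 1.3-fold lower number from compound 3 to compound 4 (0.11 log units; within the scatter) and so gives no separation between the two arrangements. The earlier compounds did not show this reversed amide with the pyrrolidine on the carbonyl at this chain length, and neither its comparison with the chain-extended amide, a 2.0-fold lower number from compound 2 to compound 4 (0.29 log units; within the scatter), the widest gap in the set, nor the comparison with the diethylamide, a 1.8-fold lower number from compound 1 to compound 4 (0.25 log units; within the scatter), leaves the scatter, so on this read-out the position has so far tolerated every side chain shown. Nothing at hand bears on why these numbers lie so close together.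

Going by these compounds, all four compounds vary only on this one amine nitrogen, so how this assay responds to changes elsewhere on the shared core stays open. On these data alone, it also stays open whether a carboxylic acid, a primary amine or a longer chain at the end of this side chain would give a step beyond the scatter.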